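Amino in place of bromo: a related substitution on the phenyl ring

The source may report more compounds than this note shows. Statements on the series, on what has been measured and on what is new or still open speak of the compounds shown alone.

Compound 1 `COc1cc(-c2cccc3nc(-c4ccccc4)oc23)cc(OC)c1OC` is the starting point. Among the compounds with values here, in a functional assay on A549 cells (Homo sapiens) for antiproliferative activity, read by MTT assay, with a stated time of 48 h (on this read-out higher numbers stand for weaker inhibition and lower numbers for stronger inhibition), compound 1 gives 20300 nM, the highest of the two numbers measured so far, so it is the weaker of the two on this read-out. Within the data shown here, the one neighbour is compound 2 `COc1cc(-c2cccc3nc(-c4cccc(Br)c4)oc23)cc(OC)c1OC`, which in this assay gives 2100 nM; the step of a 9.7-fold lower number from compound 1 to compound 2 (0.99 log units; beyond the scatter) describes a bromo in place of hydrogen on an aromatic carbon.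

Compound 3 `COc1cc(-c2cccc3nc(-c4cccc(N)c4)oc23)cc(OC)c1OC` carries the change (amino in place of hydrogen on an aromatic carbon). The group enters at the same place on the same ring as the bromo of compound 2, so that single measured step is the only one bearing on it. The two groups differ in kind, however, and nothing measured shows how an amino group behaves here, so the bromo step can guide the direction but not the size. A lower number than compound 1 is expected for compound 3, most likely a step of a 2.9-fold lower number from compound 1 to compound 3 (0.46 log units; beyond the scatter), smaller than the bromo step and with wide uncertainty. Compound 3 is therefore estimated at 7000 nM, within a range from 1500 nM to 30000 nM.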

Compound 3, half-maximal inhibitory concentration: 4700 nM
Compound 3: the middle estimate sits 1.5-fold (0.17 log units) above what was measured; measured number inside the range.
By their numbers in this assay, from the lowest: compound 2; then compound 3; then compound 1.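

In this assay, the amino group of compound 3 is a second group at this place on the phenyl ring that lowers the number, with a 4.3-fold lower number from compound 1 to compound 3 (0.64 log units; beyond the scatter), so the gain over the bare phenyl of compound 1 is no longer tied to bromo alone. The two groups are not interchangeable, however: replacing bromo with amino gives a 2.2-fold higher number from compound 2 to compound 3 (0.35 log units; beyond the scatter), which shows that the kind of group entering here affects the size of the change and that bromo holds the lower number of this pair. Nothing available accounts for either step or for the gap between the two groups.

The compounds shown leave open how a hydroxyl, a carboxylic acid or a longer chain ending in an amine would fare at this same place, and so whether any group can bring the number below that of compound 2. They also leave open whether an amide built on the nitrogen of compound 3 would keep its gain over compound 1, and whether either group would give a similar step elsewhere on the phenyl ring.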